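Phenyl in Place of Bromo: Expectation for Compound 4

This account rests on a few compounds, and the source may have more. Where it says the series, first, only, none or still open, it means among the compounds named here.

In an assay on CHO cells for displacement of a labelled ligand from adenosine receptor A1 (Homo sapiens), read by scintillation counting, tested at 10 uM (a lower number here means less inhibition, a higher number more inhibition at the concentration tested (going by the name of the read-out)), the three measured compounds give:
compound 1 `Cc1c(-c2ccccc2)sc(N)c1C(=O)c1ccc(Cl)cc1`: 1%
compound 2 `Cc1c(Br)sc(N)c1C(=O)c1ccc(Cl)cc1`: 1%
compound 3 `CC(C)(C)Cc1c(Br)sc(N)c1C(=O)c1ccc(Cl)cc1`: 1%

All three share one core and all three sit at the same level in this assay within the scatter of the measurement. Going from compound 2 to compound 1, the change is phenyl in place of bromo on an aromatic carbon, and the step is no change at the digits printed from compound 2 to compound 1 (within the scatter). Going from compound 2 to compound 3, the change is tert-butyl in place of hydrogen on a saturated chain carbon bound to an aromatic carbon, and the step is no change at the digits printed from compound 2 to compound 3 (within the scatter). Neither change moved the read-out.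

Compound 4 `CC(C)(C)Cc1c(-c2ccccc2)sc(N)c1C(=O)c1ccc(Cl)cc1` has not been measured. It differs from compound 3 by phenyl in place of bromo on an aromatic carbon. Within the data shown here, this is the same kind of change as the one from compound 2 to compound 1, but not the same change: in the earlier pair the ring atom next to the changed carbon bears a methyl group, whereas in compound 3 and compound 4 that ring atom bears a neopentyl group.

Since the step from compound 2 to compound 1 was no change at the digits printed from compound 2 to compound 1 (within the scatter), and since compound 3 gives 1%, the step from compound 3 to compound 4 is expected to be a number 1 percentage points higher from compound 3 to compound 4 (within the scatter), staying within the scatter. Compound 4 is therefore estimated at 2% in this assay, expected to lie between -8% and 12%. Among the measured compounds shown here, this rests on only two measured steps, and a larger move cannot be ruled out.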

Compound 4, a percentage reported as inhibition, at one concentration (the size of the read-out at that concentration, not a potency): 1%
Beside the measured number, compound 4's estimate is 1 percentage points above it; measured number inside the range.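

In this assay, phenyl in place of bromo on the core that bears the neopentyl group gives no change at the digits printed from compound 3 to compound 4 (within the scatter), and this matches what the same change did on the core that bears the methyl group: the same change on two cores in this assay, no change at the digits printed (within the scatter) from compound 2 to compound 1 and no change at the digits printed (within the scatter) from compound 3 to compound 4, 0 percentage points apart, within the scatter of two such steps

The other change in this set of four compounds, tert-butyl in place of hydrogen on the saturated chain carbon, also gives no change at the digits printed from compound 1 to compound 4 (within the scatter), so it too reads the same with phenyl as with bromo on the ring: the same change on two cores in this assay, no change at the digits printed (within the scatter) from compound 2 to compound 3 and no change at the digits printed (within the scatter) from compound 1 to compound 4, 0 percentage points apart, within the scatter of two such steps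

This shows that, among these four compounds, neither change moves the read-out on either core, but all four sit at the same low level, so the agreement is only between steps that show no change, and it does not show that either change would carry over on a compound with clear inhibition.

The compounds shown leave open whether any other group in place of bromo or phenyl, such as a carboxylic acid or an amine on a longer chain, would move the read-out at all. They also leave open whether replacing the amino group on the shared core would do so.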